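This account rests on a few compounds, and the source may have more. Where it says the series, first, only, none or still open, it means among the compounds named here.

Measured compounds in a functional assay on HCC 2998 cells (Homo sapiens) for inhibition, read by sulforhodamine B assay, with a stated time of 48 h; on this read-out higher numbers stand for weaker inhibition of growth and lower numbers for stronger inhibition of growth:
Compound 1 `O=C(Nc1cccc(-n2cc(-c3ccncc3)c(-c3ccc(Cl)c(O)c3)n2)c1)Nc1ccc(Cl)c(Cl)c1`: 13900 nM
Compound 2 `COc1cc(-c2nn(-c3cccc(NC(=O)c4ccc(Cl)c(C(F)(F)F)c4)c3)cc2-c2ccncc2)ccc1Cl`: > 32500 nM

Compound 2 is the starting point of the step followed here. In this assay the figure for compound 2 is a limit of the assay rather than a measured number. Compound 2 thus stands at the limit of > 32500 nM in this assay, at which 1 of the 2 values shown sits, and how far beyond that point its true value lies is not known. For the measured compounds named here, compound 1 is the only compound with a definite number, and its structure differs from that of compound 2 in more than one place, so the two values cannot be read as the effect of any single change.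

Compound 3 `COc1cc(-c2nn(-c3cccc(NC(=O)c4cccc(C(F)(F)F)c4)c3)cc2-c2ccncc2)ccc1Cl` differs from compound 2 in one place: hydrogen in place of chloro on an aromatic carbon. Going by the values given here, no measured pair shows what this change does in this assay, so no direction can be taken from the data. The step expected is small, within the usual scatter, and compound 3 is therefore expected to remain close to the limit. The expected step is an at least 1.0-fold lower number from compound 2 to compound 3 (0.03 log units; that floor lies within the scatter). The estimated value for compound 3 is 30000 nM, with a range from 10000 nM to 100000 nM.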

Compound 3, concentration for total growth inhibition: 17600 nM
Compound 3: the middle estimate sits 1.7-fold (0.23 log units) above what was measured; low and high end bracket the measured number.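

The figure for compound 2 is a limit of the assay and not a number: the limit of > 32500 nM in this assay, at which 1 of the 3 values shown sits.

For the compounds shown here, with compound 3, this position gives the first single change that can be read in this assay, as swapping the 4-chloro-3-(trifluoromethyl)phenyl group for 3-(trifluoromethyl)phenyl gives an at least 1.8-fold lower number from compound 2 to compound 3 (0.26 log units; that floor lies within the scatter). Compound 3 has a definite value of 17600 nM, so losing the chloro ortho to the trifluoromethyl group still leaves growth inhibition that can be given as a number. As far as these compounds go, the true size of the step stays unknown, and what can be read of it does not alone show a change beyond the scatter.

Still open, from the compounds shown here alone, is what other groups at this position, such as a fluoro, a methyl, an amine or a nitrile, would do to the number in this assay. Also open, going by these compounds, is whether the trifluoromethyl group matters here, since it stays in place in both compound 2 and compound 3, and one step on one cell line cannot show whether the same swap would act alike on other parts of the series.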